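Methoxyphenyl pyrazole ester with a nitrophenoxy tail

A few compounds are considered here, and "the series" means these few. Any claim that something is new, unique, unknown or untested is made for them only; others in the source may bear on it.

Compound 2 `CCOC(=O)c1cc(-c2ccc(OC)cc2)nn1CC(O)COc1ccc(Cl)cc1` was tested in a functional assay on A549 cells (Homo sapiens) for inhibition, read by MTT assay, with a stated time of 48 h (on this read-out higher numbers stand for weaker inhibition and lower numbers for stronger inhibition), where compound 2 gives 38000 nM. Compound 1 `CCOC(=O)c1cc(-c2ccc(Cl)cc2)nn1CC(O)COc1ccccc1[N+](=O)[O-]` in this assay gives 26000 nM, and the two numbers lie within the usual scatter of each other, so compound 2 stands alongside compound 1 rather than apart from it. Compound 3 `CCOC(=O)c1cc(-c2ccc(OC)cc2)nn1CC(O)COc1ccccc1[N+](=O)[O-]` differs from compound 2 by 2-nitrophenyl in place of 4-chlorophenyl on an oxygen on a saturated carbon. For the measured compounds named here, no measured pair isolates this change; given compound 1 at 26000 nM, the step from compound 2 to compound 3 is expected to be small, a 1.3-fold lower number from compound 2 to compound 3 (0.10 log units; within the scatter), with no clear direction beyond the scatter. Compound 3 is estimated at 30000 nM, in the range 12000 nM to 80000 nM.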

Compound 3, half-maximal inhibitory concentration: 45000 nM
Compound 3: the middle estimate sits 1.5-fold (0.18 log units) below what was measured; measured number inside the range.
By their numbers in this assay, from the lowest: compounds 1, 2 and 3 (each within the scatter of the next).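

At this place, on an oxygen on a saturated carbon, 2-nitrophenyl in place of 4-chlorophenyl gives a 1.2-fold higher number from compound 2 to compound 3 (0.07 log units; within the scatter) in this assay and so separates the two compounds by no more than the usual scatter. With the 2-nitrophenoxy tail held fixed, methoxy in place of chloro on an aromatic carbon gives a 1.7-fold higher number from compound 1 to compound 3 (0.24 log units; within the scatter) and likewise leaves the two compounds unseparated. Nothing available here accounts for either step. The compounds shown leave open whether an amine or a carboxylic acid in place of the 2-nitrophenyl on that oxygen would move the number beyond the scatter.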